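Replacing bromo with methylpiperazinyl on the amide aryl ring

This account rests on a few compounds, and the source may have more. Where it says the series, first, only, none or still open, it means among the compounds named here.

Compound 1 `CC1(C)c2[nH]nc(NC(=O)c3ccc4ncccc4c3)c2CN1Cc1cc(F)cc(F)c1` gives 180 nM in an assay on Sf21 cells for inhibition of high affinity nerve growth factor receptor (Homo sapiens), read by HTRF, with a stated time of 30 min, in the presence of a further agent that is not named here; a lower number here means a stronger inhibitor, a higher number a weaker inhibitor; compound 2 `CC1(C)c2[nH]nc(NC(=O)c3ccc(Br)cc3)c2CN1Cc1cc(F)cc(F)c1` gives 710 nM in this assay.

Within the data shown here, compound 2 stands as the higher of the two numbers, and the only measured step is a 3.9-fold higher number from compound 1 to compound 2 (0.60 log units; beyond the scatter). Compound 3 `CN1CCN(c2ccc(C(=O)Nc3n[nH]c4c3CN(Cc3cc(F)cc(F)c3)C4(C)C)cc2)CC1` differs from compound 2 by 4-methylpiperazin-1-yl in place of bromo on an aromatic carbon. Among the measured compounds shown here, no measured step touches this group, so nothing bears directly on it; the one step known concerns a different change. Compound 3 is therefore expected to sit near compound 2, with a 1.8-fold lower number from compound 2 to compound 3 (0.25 log units; within the scatter) as the estimated step, giving an estimate of 400 nM in this assay within 100 nM to 1600 nM.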

Compound 3, half-maximal inhibitory concentration: 17 nM
Estimate against measurement, compound 3: 24-fold (1.37 log units) above; measured number below the stated range.
By their numbers in this assay, from the lowest: compound 3; then compound 1; then compound 2.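

In this assay the change to 4-methylpiperazin-1-yl on this aromatic carbon gives a 42-fold lower number from compound 2 to compound 3 (1.62 log units; beyond the scatter) and so counts as large, whereas the earlier compounds had shown only the modest 3.9-fold higher number from compound 1 to compound 2 (0.60 log units; beyond the scatter) on changing the whole aryl group. This aromatic carbon therefore accepts a six-membered non-aromatic ring in place of a single bromine, and the number falls sharply. No evidence here bears on why the number falls so far. Still open, going by these compounds, is whether morpholine, piperidine or an unmethylated piperazine at this carbon would give a similar number.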